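Second hydroxyl on the aryl hydrazone

This account rests on a few compounds, and the source may have more. Where it says the series, first, only, none or still open, it means among the compounds named here.

Compound 1 `C/C(=N\NC(=O)c1cccc(S(=O)(=O)N2CCOCC2)c1)c1cccc(N)c1` is tested in a functional assay on ECa-109 cells for antiproliferative activity against ECa-109 cell line (Homo sapiens), read by MTT assay, with a stated time of 72 h (on this read-out higher numbers stand for weaker inhibition and lower numbers for stronger inhibition), and gives > 100000 nM, a limit rather than a number. That limit is the limit of > 100000 nM in this assay, at which 1 of the 2 values shown sits. Within the data shown here, compound 2 `C/C(=N\NC(=O)c1cccc(S(=O)(=O)N2CCOCC2)c1)c1ccc(O)cc1` gives 88300 nM in this assay and holds the only numeric value. The step of an at least 1.1-fold lower number from compound 1 to compound 2 (0.05 log units; that floor lies within the scatter) stays within the scatter. Compound 3 `C/C(=N\NC(=O)c1cccc(S(=O)(=O)N2CCOCC2)c1)c1cc(O)ccc1O` brings (2,5-dihydroxyphenyl in place of 4-hydroxyphenyl on a carbon with a double bond to nitrogen). Among the measured compounds shown here, only the step of an at least 1.1-fold lower number from compound 1 to compound 2 (0.05 log units; that floor lies within the scatter) bears on this change, and it lies within the scatter, so no shift beyond the scatter is expected in this assay. Compound 3 is estimated at 70000 nM, between 25000 nM and 200000 nM. The expected step is a 1.3-fold lower number from compound 2 to compound 3 (0.10 log units; within the scatter).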

Compound 3, half-maximal inhibitory concentration: 21400 nM
The estimate for compound 3 lay 3.3-fold (0.51 log units) above the measured number, and the stated range ends above it.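

In this assay, among these compounds, 2,5-dihydroxyphenyl in place of 4-hydroxyphenyl is the first change at this carbon to move the number beyond the scatter: a 4.1-fold lower number from compound 2 to compound 3 (0.62 log units; beyond the scatter). Against the 3-aminophenyl group, the change gives an at least 4.6-fold lower number from compound 1 to compound 3 (0.66 log units; beyond the scatter). That step has only a floor, as compound 1 stands at a limit rather than a number: the limit of > 100000 nM in this assay, at which 1 of the 3 values shown sits.

From the compounds shown here alone, whether the free hydroxyl groups themselves matter stays open. A 2,5-dimethoxyphenyl group on the same carbon would address this, and a 2,5-diaminophenyl group would show whether an amine can take their place.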